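The compounds below may be only part of what the source reports. "The series", "measured", "known", "first", "only" and "open" are said of these compounds alone.

Working notes on the series. Three measured compounds share one extended scaffold and differ in the group on an aromatic nitrogen: compound 1 `COC1=C(OC)C(=O)C(CCCCCCCCCCn2cc(C[C@H](O)COCCOC[C@@H](O)Cc3ccc(-c4ccccc4)cc3)nn2)=C(C)C1=O`, compound 2 `O=C1COc2ccc(-n3cc(C[C@H](O)COCCOC[C@@H](O)Cc4ccc(-c5ccccc5)cc4)nn3)cc2N1` and compound 3 `O[C@H](COCCOC[C@@H](O)Cc1cn(Cc2cccc(-c3ccccc3)c2)nn1)Cc1ccc(-c2ccccc2)cc1`. In a functional assay on SGC-7901 cells (Homo sapiens) for inhibition, read by MTT assay, with a stated time of 72 h (a higher number here means a weaker inhibitor of growth, a lower number a stronger inhibitor of growth), compound 1 gives 3800 nM, compound 2 gives 15200 nM and compound 3 gives 10600 nM. Compound 2 therefore holds the highest of the three numbers. Its gap to compound 3 lies within the scatter, so the two cannot be ordered on these data. Its gap to compound 1 lies beyond the scatter, and compound 1 is the stronger inhibitor of growth of that pair.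

Compound 4 `O=c1[nH]c2ccc(-n3cc(C[C@H](O)COCCOC[C@@H](O)Cc4ccc(-c5ccccc5)cc4)nn3)cc2s1` is not yet measured. Relative to compound 2 the change is a group of 10 heavy atoms (7 carbon, 1 nitrogen, 1 oxygen, 1 sulfur; one five-membered aromatic ring with 2 hetero atoms, one six-membered aromatic ring of carbon only) in place of a group of 11 heavy atoms (8 carbon, 1 nitrogen, 2 oxygen; one six-membered non-aromatic ring with 2 hetero atoms, one six-membered aromatic ring of carbon only), on an aromatic nitrogen, that is, a group of 10 heavy atoms in place of a group of 11 heavy atoms, on an aromatic nitrogen. Both groups keep one hydrogen-bond donor and two hydrogen-bond acceptors and one double bond outside aromatic rings; the aromatic six-membered ring of carbon only is retained, and the non-aromatic six-membered ring becomes a five-membered aromatic ring. For the measured compounds named here, no measured pair in the set reports a step of this kind, so the expectation rests on the closeness of the two groups alone. The step of a 1.3-fold lower number from compound 2 to compound 4 (0.10 log units; within the scatter) is expected to stay within the scatter, with no clear direction. For compound 4 in this assay the estimate is 12000 nM, with a range from 5000 nM to 30000 nM.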

Compound 4, concentration for 50% growth inhibition: 10500 nM
For compound 4 the middle estimate is 1.1-fold (0.06 log units) above the measured one, within the range that was stated.
By their numbers in this assay, from the lowest: compound 1; then compounds 4, 3 and 2 (each within the scatter of the next).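

In this assay, for the compounds shown here, this is the first step between two groups of close composition on an aromatic nitrogen, and it reads as follows (a 1.4-fold lower number from compound 2 to compound 4 (0.16 log units; within the scatter)). At this position, then, the six-membered non-aromatic ring with 2 hetero atoms can give way to a five-membered aromatic ring with 2 hetero atoms, one of them sulfur, with no difference that this assay can resolve, so compound 2 and compound 4 cannot be ordered; both groups keep the six-membered aromatic ring of carbon only and the same counts of hydrogen-bond donors and acceptors. No measurement bears on why the two numbers stand so close.

The step alters ring size, aromatic character and the hetero atom together, so a group with oxygen in place of the sulfur would be needed to tell these apart. Going by these compounds, how an amine or a carboxylic acid on this aromatic nitrogen would read in this assay also remains open.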